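Changing the Side Chain Where Cytotoxicity Has Not Appeared

The compounds below may be only part of what the source reports. "The series", "measured", "known", "first", "only" and "open" are said of these compounds alone.

Compound 1 `O=C1CSC(=O)N1C[C@H]1CN(c2ccc(-n3cc(-c4ccccn4)cn3)c(F)c2)C(=O)O1` and compound 2 `O=C(OC[C@H]1CN(c2ccc(-n3cc(-c4ccccn4)cn3)c(F)c2)C(=O)O1)c1ccccc1` share one core and differ only in the group carried on a saturated chain carbon bound to a saturated ring carbon. In an ADME assay on L02 cells (Homo sapiens) for cytotoxicity, read by MTT assay, with a stated time of 48 h (on this read-out lower numbers stand for stronger inhibition and higher numbers for weaker inhibition), compound 1 reaches only a limit of the assay, > 400 ug/mL. In this assay compound 2 likewise stops at a limit, > 400 ug/mL. The step that the two limits leave unreadable from compound 1 to compound 2 is therefore not readable in size or direction; what the two measurements share is the limit of > 400 ug/mL in this assay, at which 2 of the 2 values shown sit, and this is all that the series shows so far.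

Compound 3 `O=C1O[C@@H](CSc2cccs2)CN1c1ccc(-n2cc(-c3ccccn3)cn2)c(F)c1` introduces ((thiophen-2-yl)sulfanyl in place of benzoyloxy on a saturated chain carbon bound to a saturated ring carbon). Within the data shown here, the only measured step at this position is the one from compound 1 to compound 2, and it gives no size to lean on. With no readable step and both known values resting at a limit, no movement beyond the scatter is expected, and the step of a number no higher from compound 2 to compound 3 (the limit leaves the size open) is estimated to be flat. Compound 3 is expected to give 400 ug/mL in this assay, within 200 ug/mL to 800 ug/mL, most probably reported again as a limit.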

Compound 3, half-maximal inhibitory concentration: > 400 ug/mL
Compound 3 ended at the assay's limit; the forecaster's own chance of this, stated with the estimate: 75%; the middle value lies on the limit itself.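

Compound 3 also stops at a limit in this assay, > 400 ug/mL. No step among compound 1, compound 2 and compound 3 can be read, in size or in direction: the limit of > 400 ug/mL in this assay, at which 3 of the 3 values shown sit.

Going by these compounds, whether the group on a saturated chain carbon bound to a saturated ring carbon changes the read-out in this assay at all remains open.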